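The compounds below may be only part of what the source reports. "The series", "measured", "known", "first", "only" and "open" are said of these compounds alone.

Within the data shown here, compound 2 `CCCCc1cn(C[C@H](O)[C@H]2OC(=O)C(OCc3ccccc3)=C2OCc2ccccc2)nn1` is the only compound here with a number: in a functional assay on A549 cells (Homo sapiens) for antiproliferative activity, read by MTT assay, with a stated time of 72 h (a higher number here means a weaker inhibitor, a lower number a stronger inhibitor), compound 2 gives 28600 nM. Compound 1 `O=C1O/C(=C\Cn2cc(-c3cc(F)cc(F)c3)nn2)C(OCc2ccccc2)=C1OCc1ccccc1` gives only a limit of this assay, > 100000 nM. Compound 3 `COc1ccc(-c2cn(C/C=C3\OC(=O)C(OCc4ccccc4)=C3OCc3ccccc3)nn2)cc1` likewise gives only a limit in this assay, > 100000 nM. The one-place step from compound 1 to compound 3, a step that the two limits leave unreadable from compound 1 to compound 3, cannot be read because of the limit of > 100000 nM in this assay, at which 2 of the 3 values shown sit. Compound 4 `Cc1ccc(-c2cn(C[C@H](O)[C@H]3OC(=O)C(OCc4ccccc4)=C3OCc3ccccc3)nn2)cc1` differs from compound 2 by 4-methylphenyl in place of butyl on an aromatic carbon. Among the measured compounds shown here, no measured step exchanges butyl for a ring, so the size of this change is not informed by the data; compounds 1 and 3, built on a different core, both sit at the limit. Compound 4 is therefore expected to come out similar or weaker, a step of a 1.7-fold higher number from compound 2 to compound 4 (0.24 log units; within the scatter), with an estimate of 50000 nM between 15000 nM and 150000 nM.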

Compound 4, half-maximal inhibitory concentration: 8690 nM
Compound 4: the middle estimate sits 5.8-fold (0.76 log units) above what was measured; measured number below the stated range.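

Among these compounds, putting 4-methylphenyl in place of butyl on this aromatic carbon gives the first readable change at this position in this assay, a 3.3-fold lower number from compound 2 to compound 4 (0.52 log units; beyond the scatter). The position therefore responds to the group it carries, at least on the core shared by these two compounds. The earlier exchange at this carbon, on the core of compound 1, showed no such thing because both of its ends are limits: the limit of > 100000 nM in this assay, at which 2 of the 4 values shown sit.

From the compounds shown here alone, whether the change comes from the ring itself or from its methyl group stays open. So does the outcome with an unsubstituted phenyl, a longer chain or an amine at this carbon.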